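Swapping Chloro for Dimethylamino on the Pyridine Amide

The source may report more compounds than this note shows. Statements on the series, on what has been measured and on what is new or still open speak of the compounds shown alone.

Compound 1: `CN(C)c1ccc(C(=O)N2CCC(NS(=O)(=O)c3cc(S(=O)(=O)c4ccccc4)ccc3C(F)(F)F)CC2)cc1`, 190 nM
Compound 2: `O=C(c1ccc(Cl)nc1)N1CCC(NS(=O)(=O)c2cc(S(=O)(=O)c3ccccc3)ccc2C(F)(F)F)CC1`, 140 nM

Both compounds share one core and differ only in the aromatic group attached to the carbonyl carbon. For the measured compounds named here, in an assay on U2OS cells for inhibition of secreted frizzled-related protein 1 (Homo sapiens), read by a luciferase reporter, with a stated time of 18 h (on this read-out higher numbers stand for an effect only at larger amounts of compound and lower numbers for an effect already at smaller amounts), compound 2 gives 140 nM, the lowest of the two numbers so far, while compound 1 gives 190 nM; the step of a 1.4-fold lower number from compound 1 to compound 2 (0.13 log units; within the scatter) lies within the scatter, so the two cannot be ranked. The unmeasured compound 3, `CN(C)c1ccc(C(=O)N2CCC(NS(=O)(=O)c3cc(S(=O)(=O)c4ccccc4)ccc3C(F)(F)F)CC2)cn1`, differs from compound 2 by dimethylamino in place of chloro on an aromatic carbon. Going by the values given here, the only measured step that bears on this change is a 1.4-fold lower number from compound 1 to compound 2 (0.13 log units; within the scatter), which exchanged the whole dimethylamino-bearing ring for the chloro-bearing one and moved the number little. With the ring now kept and dimethylamino returning in place of chloro, no step beyond the scatter is expected; the estimated step is a 1.2-fold higher number from compound 2 to compound 3 (0.08 log units; within the scatter). Compound 3 is therefore expected to give about 170 nM in this assay, most likely between 70 nM and 420 nM.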

Compound 3, half-maximal effective concentration: 70 nM
Compound 3: the middle estimate sits 2.4-fold (0.39 log units) above what was measured; the measured number falls inside the stated range.
By their numbers in this assay, from the lowest: compounds 3, 2 and 1 (each within the scatter of the next, the first and the last beyond it).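

In this assay, dimethylamino in place of chloro on this aromatic carbon gives a 2.0-fold lower number from compound 2 to compound 3 (0.30 log units; within the scatter) and so stays within the scatter: on these numbers the two groups cannot be told apart, although dimethylamino carries a hydrogen-bond acceptor and chloro does not. The clearer signal comes from the ring, since with dimethylamino kept, 6-(dimethylamino)pyridin-3-yl in place of 4-(dimethylamino)phenyl gives a 2.7-fold lower number from compound 1 to compound 3 (0.43 log units; beyond the scatter) and is a modest step, but the only one here beyond the scatter. No measurement available here accounts for that step.

Going by these compounds, it remains open whether a different group at this position, such as methoxy, morpholine or a carboxylic acid, would separate clearly from chloro and dimethylamino. It is also unknown whether the ring nitrogen matters in the same way with chloro on the ring, which a 4-chlorophenyl amide would test.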